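A few compounds are considered here, and "the series" means these few. Any claim that something is new, unique, unknown or untested is made for them only; others in the source may bear on it.

Measured compounds:
- Compound 1 `COc1ccc(-c2cc(C(=O)Nc3nc4ccc(Cl)cc4s3)nc3cc(-c4ccccc4)nn23)cc1OC`, in a functional assay on ACHN cells (Homo sapiens) for cytotoxicity, read by MTT assay, with a stated time of 48 h (on this read-out higher numbers stand for weaker inhibition and lower numbers for stronger inhibition), compound 1 gives 7760 nM.
- Compound 2 `COc1ccc(-c2cc(C(=O)Nc3nc4ccc(F)cc4s3)nc3cc(-c4ccccc4)nn23)cc1OC`, in this assay compound 2 gives 8120 nM.
- Compound 3 `COc1ccc2nc(NC(=O)c3cc(-c4ccc(F)cc4)n4nc(-c5ccccc5)cc4n3)sc2c1`, in this assay compound 3 gives 26300 nM.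

Compound 3 has the highest number of the three, so on this read-out it is the weakest inhibitor of the set; compounds 1 and 2 both sit clearly below it. Going by the values given here, the only single-point step measured so far is a 1.0-fold higher number from compound 1 to compound 2 (0.02 log units; within the scatter), a swap of one halogen for another on the benzothiazole part that left the number essentially unchanged.

Compound 4 `COc1ccc2nc(NC(=O)c3cc(-c4ccc(OC)c(OC)c4)n4nc(-c5ccccc5)cc4n3)sc2c1` arises from compound 3 by the change (3,4-dimethoxyphenyl in place of 4-fluorophenyl on an aromatic carbon). Among the compounds with values here, no measured step covers this exact change. What the data do show is that compounds 1 and 2, which carry the 3,4-dimethoxyphenyl group, both give lower numbers than compound 3, while their own halogen swap made no difference beyond the scatter. On that basis compound 4 is expected to move toward the values of compounds 1 and 2, giving a 2.9-fold lower number from compound 3 to compound 4 (0.47 log units; beyond the scatter). The estimate for compound 4 in this assay is 9000 nM, with a range from 4000 nM to 20000 nM.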

Compound 4, half-maximal inhibitory concentration: 13300 nM
Compound 4: the middle estimate sits 1.5-fold (0.17 log units) below what was measured, within the range that was stated.
By their numbers in this assay, from the lowest: compounds 1, 2, 4 and 3 (each within the scatter of the next, the first and the last beyond it).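

In this assay, going by these compounds alone, 3,4-dimethoxyphenyl in place of 4-fluorophenyl on this aromatic carbon gives a 2.0-fold lower number from compound 3 to compound 4 (0.30 log units; within the scatter) and is the first direct test of this change, showing that the two groups cannot be told apart here. With 3,4-dimethoxyphenyl held in place, the earlier halogen comparison also widens to methoxy: methoxy in place of fluoro gives a 1.6-fold higher number from compound 2 to compound 4 (0.21 log units; within the scatter) and methoxy in place of chloro gives a 1.7-fold higher number from compound 1 to compound 4 (0.23 log units; within the scatter). Both of these steps also lie within the usual scatter, so neither change separates the compounds in this cell assay.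

Going by these compounds, whether an amine or a carboxylic acid at this aromatic carbon would shift the number remains open. Nothing available explains why these swaps leave the numbers so close.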